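Hydroxy in Place of Methylcarbamoyl on the Aromatic Ring

A few compounds are considered here, and "the series" means these few. Any claim that something is new, unique, unknown or untested is made for them only; others in the source may bear on it.

Compound 1 `C=CC[C@H]1C[C@]2([C@@H](C)Cc3ccc(O)cc3)OCOC2=CC1=O`: in a functional assay on M14 cells (Homo sapiens) for antiproliferative activity, with a stated time of 72 h (a higher number here means a weaker inhibitor, a lower number a stronger inhibitor), compound 1 gives > 20000 nM, a limit of the assay.
Compound 2 `C=CC[C@H]1C[C@]2([C@@H](C)Cc3ccc(OC(C)=O)cc3)OCOC2=CC1=O`: in this assay compound 2 gives > 20000 nM, also a limit.
Compound 3 `C=CC[C@H]1C[C@]2([C@@H](C)Cc3ccc(OC)c(C(=O)NC)c3)OCOC2=CC1=O`: in this assay compound 3 gives 1400 nM.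

Among the compounds with values here, compound 3 thus stands as the only numbered value; the two other results are limits, as the limit of > 20000 nM in this assay, at which 2 of the 3 values shown sit, records. The step that the two limits leave unreadable from compound 1 to compound 2 is unreadable between the limits. Compound 4 `C=CC[C@H]1C[C@]2([C@@H](C)Cc3ccc(OC)c(O)c3)OCOC2=CC1=O` differs from compound 3 by hydroxy in place of methylcarbamoyl on an aromatic carbon. Within the data shown here, no measured step covers this exchange, so the expectation rests on compound 3 alone and is loose. Compound 4 is estimated at 5000 nM, within 1500 nM to 20000 nM. This corresponds to an expected step of a 3.6-fold higher number from compound 3 to compound 4 (0.55 log units; beyond the scatter), a loss that may reach the limit.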

Compound 4, half-maximal inhibitory concentration: 8 nM
The estimate for compound 4 lay 630-fold (2.80 log units) above the measured number, and the stated range ends above it.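

In this assay, hydroxy in place of methylcarbamoyl on an aromatic carbon ortho to a methoxy group brings a 180-fold lower number from compound 3 to compound 4 (2.24 log units; beyond the scatter) as a large gain. Within the data shown here, the earlier compounds gave no readable step at this position, so this is the first measure of how strongly the group held there governs the number. Nothing given here accounts for the size of this gain. Going by these compounds, whether it is particular to hydroxy remains open, since an amine or a carboxylic acid on this carbon would be needed to tell. Also open, on these data alone, is how much the hydroxy depends on the methoxy group beside which the place line sets it, for which an ethoxy group there would offer a test.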